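A few compounds are considered here, and "the series" means these few. Any claim that something is new, unique, unknown or untested is made for them only; others in the source may bear on it.

- compound 1 `Nc1sc(-c2ccc(Cl)cc2)c(-c2ccc(Cl)cc2)c1C(=O)N1CCCCC1=O` gives 1820 nM as its value
- compound 2 `Nc1sc(-c2ccc(Cl)cc2)c(-c2ccc(Cl)cc2)c1C(=O)Nc1ccccc1` gives 25000 nM as its value
- compound 3 `CC(C)(C)NC(=O)c1c(N)sc(-c2ccc(Cl)cc2)c1-c1ccc(Cl)cc1` gives 8850 nM as its value

These numbers come from a functional assay on A549 cells (Homo sapiens) for inhibition, read by sulforhodamine B assay, with a stated time of 72 h (a lower number here means a stronger inhibitor, a higher number a weaker inhibitor), and compound 3 stands in the middle of them. Compound 1 is the strongest inhibitor of the three and compound 2 the weakest.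

The next compound is compound 4 `Nc1sc(-c2ccc(Cl)cc2)c(-c2ccc(Cl)cc2)c1C(=O)NCc1ccccc1`, which has benzyl in place of tert-butyl on an amide-type nitrogen.

Among the measured compounds shown here, three measured steps bear on this change. Changing the group on the same nitrogen gave a modest step (a 2.8-fold lower number from compound 2 to compound 3 (0.45 log units; beyond the scatter)). Replacing the 2-oxopiperidin-1-yl group gave a large step (a 14-fold higher number from compound 1 to compound 2 (1.14 log units; beyond the scatter)) in one case and a modest one (a 4.9-fold higher number from compound 1 to compound 3 (0.69 log units; beyond the scatter)) in the other. Benzyl brings an aromatic ring, as the anilino group of compound 2 does, so a number between compound 3 at 8850 nM and compound 2 at 25000 nM seems likely. Only a small upward move is therefore expected, not clearly beyond the scatter (a 1.4-fold higher number from compound 3 to compound 4 (0.13 log units; within the scatter)). The estimated value for compound 4 is 12000 nM with an expected range from 4500 nM to 30000 nM in this assay.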

Compound 4, half-maximal inhibitory concentration: 16300 nM
Beside the measured number, compound 4's estimate is 1.4-fold (0.13 log units) below it; the measured number falls inside the stated range.
By their numbers in this assay, from the lowest: compound 1; then compounds 3, 4 and 2 (each within the scatter of the next, the first and the last beyond it).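

In this assay, benzyl in place of tert-butyl on the amide-type nitrogen gives a step within the scatter (a 1.8-fold higher number from compound 3 to compound 4 (0.27 log units; within the scatter)), and benzyl in place of phenyl does too (a 1.5-fold lower number from compound 2 to compound 4 (0.19 log units; within the scatter)), so compound 4 cannot be told apart from either neighbour, even though those two neighbours differ beyond the scatter. Compound 1 remains the strongest inhibitor, and the benzylamino group does not close the gap to its 2-oxopiperidin-1-yl group (a 9.0-fold higher number from compound 1 to compound 4 (0.95 log units; beyond the scatter)). No measurement shown here offers an explanation for these results.

Still open, going by these compounds, is how a longer chain such as 2-phenylethyl, or a benzyl ring carrying an amine or a carboxylic acid, would behave on this nitrogen. On these data alone, it is also open whether the smaller 2-oxopyrrolidin-1-yl group would match compound 1.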